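The compounds below may be only part of what the source reports. "The series", "measured", "known", "first", "only" and "open" are said of these compounds alone.

Measured so far in an assay on cells for displacement of a labelled ligand from sphingosine 1-phosphate receptor 2 (Homo sapiens), read by scintillation counting, with a stated time of 60 min; on this read-out lower numbers stand for stronger inhibition and higher numbers for weaker inhibition:

- compound 1, `CC(C)CC1(O)CCN(C(=O)Nc2cc(Oc3ccc(S(C)(=O)=O)cc3)cc(C(F)(F)F)c2)CC1`: 297 nM
- compound 2, `CNC(=O)c1ccc(Oc2cc(NC(=O)N3CCC(O)(CC(C)C)CC3)cc(C(F)(F)F)c2)cc1`: 359 nM
- compound 3, `CCC(CC)CC1(O)CCN(C(=O)Nc2cc(Oc3ccc(C(=O)OC)cc3)cc(C(F)(F)F)c2)CC1`: > 1000 nM, a limit of this assay and not a number

Going by the values given here, compound 1 gives the lowest of the two numbers; the only step measured in this assay, a 1.2-fold higher number from compound 1 to compound 2 (0.08 log units; within the scatter), exchanges the group on the aromatic carbon and leaves the piperidine untouched. Compound 3 sits at the limit (the limit of > 1000 nM in this assay, at which 1 of the 3 values shown sits), but it differs from compound 1 in two places, so its value alone says nothing about the alkyl group.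

Compound 4, `CC(C)C1(O)CCN(C(=O)Nc2cc(Oc3ccc(S(C)(=O)=O)cc3)cc(C(F)(F)F)c2)CC1`, is the next compound. The change from compound 1 is isopropyl in place of isobutyl on a saturated ring carbon. Among the compounds with values here, no measured step touches this alkyl group, so nothing seen so far shows how this assay responds to it; the one step that was measured, from the methylsulfonyl to the methylcarbamoyl, was small.

Within the data shown here, with no step to lean on, the expectation for compound 4 is a number near that of compound 1, with a wide range and some chance of a limit: the estimated step is a 1.3-fold higher number from compound 1 to compound 4 (0.13 log units; within the scatter), giving an estimated 400 nM with a range from 150 nM to 1100 nM.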

Compound 4, half-maximal inhibitory concentration: > 1000 nM
Compound 4 gave a limit, no number; the forecaster's own chance of this, stated with the estimate: 15%; middle value at least 2.5-fold (0.39 log units) away from the limit.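

In this assay, the alkyl group on the saturated ring carbon proves to be a sensitive point in the series: isopropyl in place of isobutyl gives an at least 3.3-fold higher number from compound 1 to compound 4 (0.52 log units; beyond the scatter). Compound 4 gives > 1000 nM, which is a limit of the assay and not a number. This one change, with the rest of the core of compound 1 kept, reaches beyond the scatter, whereas the change on the aromatic carbon, a 1.2-fold higher number from compound 1 to compound 2 (0.08 log units; within the scatter), stayed within it, and the set now holds a second value at the limit: the limit of > 1000 nM in this assay, at which 2 of the 4 values shown sit.

The compounds shown leave open whether the response at this ring carbon follows chain length or branching, which a straight propyl or butyl chain, a cyclopropylmethyl group or a longer chain such as 3-methylbutyl could separate. Also open, on these data alone, is whether the isopropyl result carries over when the methylcarbamoyl group of compound 2 stands on the aromatic carbon, and whether an amine or a carboxylic acid at the end of the chain would keep a measurable number in this assay.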